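Branching the Chain of Compound 3

The source may report more compounds than this note shows. Statements on the series, on what has been measured and on what is new or still open speak of the compounds shown alone.

In a functional assay on A549 cells (Homo sapiens) for antiproliferative activity, read by MTT assay, with a stated time of 48 h (on this read-out lower numbers stand for stronger inhibition and higher numbers for weaker inhibition), compound 1 (`Cc1ccc(Nc2ccc3c(c2)C(CCC(C)C)C(=O)N3)cc1`) gives 6600 nM, compound 2 (`CCCCC1(O)C(=O)Nc2ccc(Nc3ccc(C)cc3)cc21`) gives 7500 nM and compound 3 (`CCCCCC1(O)C(=O)Nc2ccc(Nc3ccc(C)cc3)cc21`) gives 8100 nM. All three values lie within the scatter of one another, so compound 3 stands level with the other two.

Compound 4 (`Cc1ccc(Nc2ccc3c(c2)C(O)(CCC(C)C)C(=O)N3)cc1`) has the same atoms as compound 3, joined differently: isopropyl in place of propyl on a saturated chain carbon, two bonds along the chain from a saturated ring carbon. This places isopropyl in place of propyl on a saturated chain carbon, two bonds along the chain from a saturated ring carbon, and the same difference reads as pentyl to isopentyl.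

Within the data shown here, the one measured step bearing on this is the chain change a 1.1-fold higher number from compound 2 to compound 3 (0.03 log units; within the scatter), which stays within the scatter. Compound 1, which also carries an isopentyl chain, gives 6600 nM, within the scatter of compound 3. No step beyond the scatter is therefore expected in this assay, and the estimated step is a 1.1-fold lower number from compound 3 to compound 4 (0.03 log units; within the scatter). Compound 4 is expected at 7500 nM, with an estimated range of 4500 nM to 12500 nM.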

Compound 4, half-maximal inhibitory concentration: 12500 nM
Compound 4: the middle estimate sits 1.7-fold (0.22 log units) below what was measured, within the range that was stated.
By their numbers in this assay, from the lowest: compounds 1, 2, 3 and 4 (each within the scatter of the next).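

In this assay, the isomeric change from pentyl to isopentyl gives a 1.5-fold higher number from compound 3 to compound 4 (0.19 log units; within the scatter) and so stays within the scatter at this position, two bonds along the chain from a saturated ring carbon. The two other changes that reach the same compound also stay within the scatter: the step measured against the shorter unbranched chain is a 1.7-fold higher number from compound 2 to compound 4 (0.22 log units; within the scatter) and the step for hydroxy in place of hydrogen on a saturated ring carbon is a 1.9-fold higher number from compound 1 to compound 4 (0.28 log units; within the scatter), so neither the branch nor the hydroxy group separates these compounds here. No measurement offered here gives a reason for these readings.

The compounds shown leave open whether a longer chain, or a chain ending in an amine or a carboxylic acid, would give a step beyond the scatter. They also leave open whether replacing the hydroxy group with an amine would do so.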